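Swapping bromo for methoxy on the benzylthio ring

The source may hold more compounds than are shown below. What is called first, only, known or untested is meant among the compounds shown, and "the series" means these compounds.

Compound 1 `C#CCNC1CCc2c(SCc3cccc(Cl)c3)cccc21` is one of two measured members of this series. In an ADME assay on isolated protein for inhibition of Amine oxidase [flavin-containing] B (Homo sapiens) (on this read-out lower numbers stand for stronger inhibition and higher numbers for weaker inhibition), compound 1 gives 1090 nM. Compound 2 `C#CCNC1CCc2c(SCc3cccc(Br)c3)cccc21` differs from it only by bromo in place of chloro on an aromatic carbon. For compound 2 this assay reports only a limit, > 100000 nM, so compound 2 stands at the top of the numbers shown (the limit of > 100000 nM in this assay, at which 1 of the 2 values shown sits). Going by the values given here, the one measured step, an at least 91-fold higher number from compound 1 to compound 2 (1.96 log units; beyond the scatter), is the only comparison available. Compound 3 `C#CCNC1CCc2c(SCc3cccc(OC)c3)cccc21` is not yet measured; it differs from compound 2 by methoxy in place of bromo on an aromatic carbon. Among the compounds with values here, no measured step involves a methoxy group, so the step cannot be read directly from the data. Because compound 2 sits at a limit (the limit of > 100000 nM in this assay, at which 1 of the 2 values shown sits), almost any numerical result for compound 3 would appear as a lower number. Compound 3 is therefore expected to give about 20000 nM, within a range from 2000 nM to 100000 nM, which means an expected step of an at least 5.0-fold lower number from compound 2 to compound 3 (0.69 log units; beyond the scatter).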

Compound 3, half-maximal inhibitory concentration: 1520 nM
For compound 3 the middle estimate is 13-fold (1.12 log units) above the measured one; measured number outside the range, below it.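

In this assay, methoxy in place of bromo gives an at least 65-fold lower number from compound 2 to compound 3 (1.81 log units; beyond the scatter), so this position is not closed to every group larger than chloro. Methoxy in place of chloro gives a 1.4-fold higher number from compound 1 to compound 3 (0.14 log units; within the scatter), so the two groups cannot be told apart here even though they differ in atoms and only methoxy counts a hydrogen-bond acceptor; among the three compounds, compound 2 alone stands apart. Compound 2 stands at a limit and not at a number: the limit of > 100000 nM in this assay, at which 1 of the 3 values shown sits.

The compounds shown leave open whether fluoro, hydroxyl or ethoxy at this place would track chloro and methoxy or fall away as bromo does. They also leave open whether an amine or a carboxylic acid here would give a number clearly lower than those of compound 1 and compound 3.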